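Replacing the side group of compound 1

The source may hold more compounds than are shown below. What is called first, only, known or untested is meant among the compounds shown, and "the series" means these compounds.

- compound 1 `CC(c1cc2cccnc2cc1F)n1cnc2ncc(-c3cnn(CCO)c3)nc21` gives 175 nM
- compound 2 `CCC(c1cc2cccnc2cc1F)n1cnc2ncc(-c3cnn(CCO)c3)nc21` is recorded as "not determined" (no result reported)
- compound 3 `CC(c1c(F)cc2ncccc2c1F)n1cnc2ncc(-c3cnn(CCO)c3)nc21` gives 83.7 nM

In a functional assay on NCI-H1993 cells (Homo sapiens) for inhibition, read by CCK-8 assay, with a stated time of 72 h (on this read-out lower numbers stand for stronger inhibition and higher numbers for weaker inhibition), compound 1 stands highest of the two numbers available, and compound 3 is its nearest neighbour. Compound 4 `CC(c1cc2cccnc2cc1F)n1cnc2ncc(-c3ccc(C(N)=O)c(F)c3)nc21` has not yet been measured. It differs from compound 1 at one place on the shared core (4-carbamoyl-3-fluorophenyl in place of 1-(2-hydroxyethyl)-1H-pyrazol-4-yl on an aromatic carbon), on an aromatic carbon next to the ring nitrogen.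

For the measured compounds named here, only one measured step exists (a 2.1-fold lower number from compound 1 to compound 3 (0.32 log units; beyond the scatter)), a fluoro in place of hydrogen on an aromatic carbon. It is modest but beyond the scatter. It lies at a different place and swaps a single atom rather than a whole group, so it offers only a rough sense of scale. Going by the values given here, no measurement yet shows what a change at the place altered in compound 4 does, so the direction is a loose guess. A modest move to a lower number is expected (a 2.5-fold lower number from compound 1 to compound 4 (0.40 log units; beyond the scatter)), and a step of no size or in the opposite direction remains possible. Compound 4 is estimated at 70 nM with an expected range from 12 nM to 400 nM on this read-out.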

Compound 4, half-maximal inhibitory concentration: 19.5 nM
Compound 4: the middle estimate sits 3.6-fold (0.56 log units) above what was measured; low and high end bracket the measured number.
By their numbers in this assay, from the lowest: compound 4; then compound 3; then compound 1.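

In this assay, for the compounds shown here, this is the first measured change at the aromatic carbon next to the ring nitrogen, and it gives a 9.0-fold lower number from compound 1 to compound 4 (0.95 log units; beyond the scatter) on swapping 1-(2-hydroxyethyl)-1H-pyrazol-4-yl for 4-carbamoyl-3-fluorophenyl. So this place on the shared core can affect the read-out, and here a five-membered aromatic ring with 2 hetero atoms is not required for stronger inhibition. No supporting data are given that could explain the drop in the number.

The swap alters the ring and its substituents together, so the compounds shown do not separate the contributions of the carbamoyl group, the fluorine and the carbon-only ring. A plain phenyl, a phenyl carrying carbamoyl without fluorine, or a carboxylic acid or nitrile in place of the carbamoyl would each test one of these parts.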